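Swapping methoxy for 1H-imidazol-4-yl in compound 2

This account rests on a few compounds, and the source may have more. Where it says the series, first, only, none or still open, it means among the compounds named here.

Of the compounds shown here, three have been tested so far in a functional assay, read by Griess assay, with a stated time of 2.5 h; a higher number here means a weaker inhibitor, a lower number a stronger inhibitor. Compound 1 `COc1cc(OC)c(OC)cc1/C=C/C(=O)c1cc(OC(C)=O)ccc1OC(C)=O` gives 2.37 ug/mL, compound 2 `COc1ccc(C(=O)/C=C/c2cc(OC)c(OC)cc2OC)cc1` gives 2.07 ug/mL, and compound 3 `COc1cc(OC)c(-c2cc(=O)c3ccc(O)cc3o2)cc1OC` gives 2.27 ug/mL. These numbers lie within the usual scatter of repeated measurements, so compound 2 stands level with the other two.

Compound 4 `COc1cc(OC)c(OC)cc1/C=C/C(=O)c1ccc(-c2c[nH]cn2)cc1` has not yet been measured. It differs from compound 2 in one place, with 1H-imidazol-4-yl in place of methoxy on an aromatic carbon, para to a large group (1H-imidazol-4-yl in place of methoxy on an aromatic carbon).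

Among the measured compounds shown here, no measured pair of compounds shows a single change of this kind, so the data give no direct size for it. For the measured compounds named here, the only guide is that compound 1, at 2.37 ug/mL, and compound 3, at 2.27 ug/mL, have different structures yet sit level with compound 2, at 2.07 ug/mL. The expected change is a 1.2-fold lower number from compound 2 to compound 4 (0.09 log units; within the scatter), which would stay within the scatter. For compound 4 the estimated value is 1.7 ug/mL, with an expected range from 0.6 ug/mL to 4.5 ug/mL.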

Compound 4, half-maximal inhibitory concentration: 1.97 ug/mL
For compound 4 the middle estimate is 1.2-fold (0.06 log units) below the measured one; measured number inside the range.
By their numbers in this assay, from the lowest: compounds 4, 2, 3 and 1 (each within the scatter of the next).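

Replacing methoxy with 1H-imidazol-4-yl on this aromatic carbon, para to a large group, gives a 1.1-fold lower number from compound 2 to compound 4 (0.02 log units; within the scatter) in this assay, so the two compounds read alike. Among the compounds shown here, this is the first comparison in the set that differs in only one place, and it shows that the position can carry a group of five heavy atoms, with a five-membered aromatic ring and a hydrogen-bond donor, in place of a group of two heavy atoms and no ring, with no reading outside the scatter. No available evidence explains why the two groups read alike.

Still open, going by these compounds, is whether the same carbon would give a similar reading with a different kind of group, such as an amine or a carboxylic acid. A single step also cannot separate any contribution of the ring in 1H-imidazol-4-yl from that of its hydrogen-bond donor.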